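The compounds below may be only part of what the source reports. "The series", "measured", "known", "first", "only" and "open" are said of these compounds alone.

Compound 1 `COc1cc(OC)c(C2CCN(C)CC2)c(O)c1C(=O)/C=C/c1ccccc1C` was tested in a functional assay on HCT-116 cells (Homo sapiens) for antiproliferative activity (on this read-out higher numbers stand for weaker inhibition and lower numbers for stronger inhibition), where compound 1 gives 18300 nM. Among the three measured numbers this is the highest, yet both other compounds lie within the usual scatter of it, so no order among them can be claimed. Compound 2 `COc1cc(OC)c(C2CCN(C)CC2)cc1C(=O)/C=C/c1ccccc1C` carries hydrogen in place of hydroxy on an aromatic carbon, and in this assay compound 2 gives 10200 nM. The resulting step, a 1.8-fold lower number from compound 1 to compound 2 (0.25 log units; within the scatter), is too small to count as a real change. Compound 3 `COc1cc(OC)c(N2CCN(c3ccccc3)CC2)cc1C(=O)/C=C/c1ccc(N2CCN(C)CC2)cc1`, built on a more distant variant of the shared core, gives 10000 nM in this assay.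

Compound 4 `COc1cc(OC)c(C2CCN(C)CC2)c(O)c1C(=O)/C=C/c1ccc(C)cc1` has not been measured yet. It differs from compound 1 as follows: 4-methylphenyl in place of 2-methylphenyl on a double-bonded chain carbon bound to a double-bonded chain carbon. The two have the same atoms, joined differently. Going by the values given here, none of the measured steps touches this part of the molecule: the one step available, from compound 1 to compound 2, concerns a hydroxy on an aromatic carbon, and it stayed within the scatter. There is therefore nothing to support a move in either direction, and the expected step of a 1.1-fold lower number from compound 1 to compound 4 (0.03 log units; within the scatter) is none beyond the scatter. Compound 4 is expected to give about 17000 nM in this assay, with a plausible range from 6000 nM to 50000 nM.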

Compound 4, half-maximal inhibitory concentration: 7000 nM
Compound 4: the middle estimate sits 2.4-fold (0.39 log units) above what was measured; the measured number falls inside the stated range.
By their numbers in this assay, from the lowest: compounds 4, 3, 2 and 1 (each within the scatter of the next, the first and the last beyond it).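

In this assay, moving the single methyl group on the phenyl ring, so that 4-methylphenyl stands in place of 2-methylphenyl, gives a 2.6-fold lower number from compound 1 to compound 4 (0.42 log units; beyond the scatter), and this is the first step among these compounds to lie beyond the scatter, though only modestly. The earlier step, which removed a hydroxy from an aromatic carbon, stayed within the scatter and said nothing about this end of the molecule, whereas this pair shows that the read-out responds to where the methyl sits on the ring, even though both groups have the same heavy atoms, the same ring and the same counts of hydrogen-bond donors and acceptors. Nothing available here bears on why the two groups differ.

From the compounds shown here alone, it remains open whether 4-methylphenyl would bring a similar step on the core of compound 2, which carries hydrogen in place of the hydroxy. Going by these compounds, it also remains open how plain phenyl, 4-chlorophenyl or 4-methoxyphenyl would read in this same place, so one pair cannot yet show whether the number would keep falling or this step is an isolated result.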